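The compounds below may be only part of what the source reports. "The series", "measured", "known", "first", "only" and "open" are said of these compounds alone.

Three compounds of this series were tested in an ADME assay (liver) for metabolic stability, with Liver microsome (Homo sapiens) as the target, using microsomes, with a stated time of 10 min; a higher number here means that more of the compound is left, a lower number that less of the compound is left. Compound 1 `CCCc1cnc(N2CCC(C3Cc4cc(C5=CCN(S(=O)(=O)CCC)CC5)ccc4O3)CC2)nc1` gives 71% in this assay. Compound 2 `CCCc1cnc(N2CCC(C3Cc4c(ccc(C5=CCN(S(=O)(=O)CCC)CC5)c4F)O3)CC2)nc1` differs from compound 1 in one place, (fluoro in place of hydrogen on an aromatic carbon), and in this assay compound 2 gives 87%. That single change made a step of a number 16 percentage points higher from compound 1 to compound 2 (beyond the scatter). Compound 3 `CCCc1cnc(N2CCC(C3Cc4cc(C5=CCN(S(=O)(=O)CCCO)CC5)cc(F)c4O3)CC2)nc1` is built on a different core; how its core differs from that of compound 1 is not broken down here. In this assay compound 3 gives 100%, the highest of the three numbers, with its gap to compound 2 and its gap to compound 1 both beyond the scatter.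

Compound 4 `CCCc1cnc(N2CCC(C3Cc4c(F)c(C5=CCN(S(=O)(=O)CCCO)CC5)cc(F)c4O3)CC2)nc1` has not yet been measured. It differs from compound 3 by fluoro in place of hydrogen on an aromatic carbon. Going by the values given here, this is the same kind of change as the one from compound 1 to compound 2, but not the same change: in compound 4 the entering fluoro sits para to a fluoro group (1 heavy atom), a neighbour the place in compound 2 did not have. The earlier change raised the number by a modest step, yet because compound 3 already gives 100% there is no room for a rise of that size, and only a step of a number 3 percentage points lower from compound 3 to compound 4 (within the scatter) is expected. Compound 4 is therefore expected to give about 97% in this assay, with a likely range from 86% to 100%.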

Compound 4, percent of the compound remaining: 89%
The estimate for compound 4 lay 8 percentage points above the measured number; measured number inside the range.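

In this assay, fluoro in place of hydrogen on an aromatic carbon did not carry over from one core to the other with the same sign, as the core of compound 3 showed a number 11 percentage points lower from compound 3 to compound 4 (beyond the scatter). Set beside the earlier step, the new one shows that the result of this change on one core cannot be taken over to the other in this series: the same change on two cores in this assay, a number 16 percentage points higher (beyond the scatter) from compound 1 to compound 2 and a number 11 percentage points lower (beyond the scatter) from compound 3 to compound 4, 27 percentage points apart, beyond the scatter of two such steps It does not show why the two steps part, since the cores differ and the entering fluoro in compound 4 sits para to a fluoro group, while compound 3 stands at 100%, so that no rise could have been read from it, and with a single pair on each core these points cannot be separated.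

The compounds shown leave open whether a chloro or methyl group at the same place would follow the fluoro on either core. They also leave open whether the step would hold with a longer chain, an amine or a carboxylic acid on the sulfonyl group in place of the chains present here.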